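A few compounds are considered here, and "the series" means these few. Any claim that something is new, unique, unknown or untested is made for them only; others in the source may bear on it.

Compound 1 `COc1cccc(/C=N/Nc2ncc3c(n2)n(C2CCCC2)c(=O)c(=O)n3C)c1` gives 45800 nM in a functional assay on HCT-116 cells (Homo sapiens) for antiproliferative activity, read by MTT assay; on this read-out higher numbers stand for weaker inhibition and lower numbers for stronger inhibition. Compound 2 `Cn1c(=O)c(=O)n(C2CCCC2)c2nc(N/N=C/c3cccc(Cl)c3Cl)ncc21` gives 26400 nM. Compound 3 `Cn1c(=O)c(=O)n(C2CCCC2)c2nc(N/N=C/c3ccco3)ncc21` gives 78700 nM.

Among these three numbers compound 3 stands highest: a 1.7-fold higher number from compound 1 to compound 3 (0.24 log units; within the scatter), and a 3.0-fold higher number from compound 2 to compound 3 (0.47 log units; beyond the scatter). Compound 4 `Cn1c(=O)c(=O)n(C2CCCC2)c2nc(N/N=C/c3cccc([N+](=O)[O-])c3)ncc21` differs from compound 3 in one place: 3-nitrophenyl in place of furan-2-yl on a carbon with a double bond to nitrogen. The two steps that bear on this change run the other way, from a six-membered aryl to furan-2-yl, and both raised the number, one within the scatter and one modestly beyond it. Reversing such a change is therefore expected to lower the number, by about a 2.2-fold lower number from compound 3 to compound 4 (0.35 log units; beyond the scatter). Compound 4 is expected to give 35000 nM in this assay, between 15000 nM and 80000 nM.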

Compound 4, half-maximal inhibitory concentration: 15200 nM
Beside the measured number, compound 4's estimate is 2.3-fold (0.36 log units) above it; the range from low to high includes it.
By their numbers in this assay, from the lowest: compounds 4, 2, 1 and 3 (each within the scatter of the next, the first and the last beyond it).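

In this assay, among these compounds, 3-nitrophenyl on the carbon with a double bond to nitrogen gives a 5.2-fold lower number from compound 3 to compound 4 (0.71 log units; beyond the scatter) and so the widest step among the four compounds, showing that this position can shift the number further than the earlier steps did. Nitro in place of methoxy on an aromatic carbon gives a 3.0-fold lower number from compound 1 to compound 4 (0.48 log units; beyond the scatter) and thus a step beyond the scatter, while replacing 2,3-dichlorophenyl gives a 1.7-fold lower number from compound 2 to compound 4 (0.24 log units; within the scatter) and leaves those two unseparated. Nothing measured here accounts for these steps. Going by these compounds, whether an amine or a carboxylic acid in place of nitro on that aromatic carbon would hold the lower number remains open.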